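Methoxy in Place of Nitro: One Measured Step, One Expected

The source may hold more compounds than are shown below. What is called first, only, known or untested is meant among the compounds shown, and "the series" means these compounds.

Four compounds share a common core and differ in the groups attached to it. Compound 1 `O=C(Nn1c(-c2cccc([N+](=O)[O-])c2)nc2c(-c3ccco3)n[nH]c2c1=O)c1cccnc1` carries a nitro group and a pyridine-derived amide, compound 2 `COc1cccc(-c2nc3c(-c4ccco4)n[nH]c3c(=O)n2NC(=O)c2cccnc2)c1` differs from it by methoxy in place of nitro on an aromatic carbon, compound 3 `CCCc1n[nH]c2c(=O)n(NC(=O)c3ccccc3)c(-c3cccc([N+](=O)[O-])c3)nc12` is a propyl-bearing relative with a benzamide, and compound 4 `CCCc1n[nH]c2c(=O)n(NC(=O)c3ccccc3)c(-c3cccc(OC)c3)nc12` is related to compound 3 by methoxy in place of nitro on an aromatic carbon. How the core of compound 1 differs from that of compound 3 is not broken down here.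

In a functional assay on DU-145 cells (Homo sapiens) for cytotoxicity, read by sulforhodamine B assay, with a stated time of 2 days, tested at 100 uM (a higher number here means more inhibition at the concentration tested (going by the name of the read-out), a lower number less inhibition), compound 1 gives 1.66%. Compound 2 gives 30.1%, and the change amounts to a number 28.4 percentage points higher from compound 1 to compound 2 (beyond the scatter). Compound 3 gives 27.8% in this assay, a number within the scatter of compound 2 and beyond the scatter from compound 1.

Compound 4 has not yet been measured in this assay. Since the place lines of the two changes read the same word for word, the change from compound 3 to compound 4 is the same change as that from compound 1 to compound 2. A rise is therefore expected, but it rests on a single measured pair and on a starting value for compound 3 that already stands where compound 2 does, so the expected step is set smaller than the measured one. The step from compound 3 to compound 4 is estimated at a number 17.2 percentage points higher from compound 3 to compound 4 (beyond the scatter). For compound 4 the expected value in this assay is 45%, with a range from 20% to 72%.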

Compound 4, a percentage reported as inhibition, at one concentration (the size of the read-out at that concentration, not a potency): 23.6%
The estimate for compound 4 lay 21.4 percentage points above the measured number; low and high end bracket the measured number.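

On the core of compound 3, the change from 3-nitrophenyl to 3-methoxyphenyl reads in this assay as a number 4.2 percentage points lower from compound 3 to compound 4 (within the scatter), so the clear step seen on the core of compound 1 does not reappear here. Methoxy in place of nitro therefore does not carry a fixed step from one core to the other in this series, and the two cores answer to the same change differently: the same change on two cores in this assay, a number 28.4 percentage points higher (beyond the scatter) from compound 1 to compound 2 and a number 4.2 percentage points lower (within the scatter) from compound 3 to compound 4, 32.6 percentage points apart, beyond the scatter of two such steps. This does not show why the two pairs part, for compound 1 and compound 3 differ in more than one place, and two pairs cannot tell which outcome is the more usual one or predict the step on any further core.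

The compounds shown leave open whether the split between the two pairs follows the propyl group, the benzamide or some other part of the core, since these parts are not varied one at a time here. They also leave open how an amine or a carboxylic acid in place of the nitro or methoxy group, or a chain longer than propyl on the core, would read in this assay.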